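Moving the Chlorine on the Aryl Ring of Compound 3

This account rests on a few compounds, and the source may have more. Where it says the series, first, only, none or still open, it means among the compounds named here.

Three measured compounds share one core and differ only in the aryl group on the double-bonded chain carbon. In a functional assay on B16-F10 cells (Homo sapiens) for cytotoxicity against B16-F10 (Mus musculus), read by MTT assay, with a stated time of 72 h (a lower number here means that less compound is needed, a higher number that more compound is needed for the effect), compound 1 `O=C1/C(=C\c2ccc(O)cc2)c2ccccc2N1c1c(Cl)cccc1Cl` gives 33 ug/mL. Compound 2 `CN(C)c1ccc(/C=C2\C(=O)N(c3c(Cl)cccc3Cl)c3ccccc32)cc1` reaches only the limit of > 100 ug/mL in this assay, a limit and not a number (the limit of > 100 ug/mL in this assay, at which 1 of the 3 values shown sits). Compound 3 `O=C1/C(=C\c2cccc(Cl)c2)c2ccccc2N1c1c(Cl)cccc1Cl` gives 8 ug/mL, the lowest number among the compounds with a measured value; its nearest neighbour is compound 1, separated by the step of a 4.1-fold lower number from compound 1 to compound 3 (0.62 log units; beyond the scatter). The other steps were an at least 3.0-fold higher number from compound 1 to compound 2 (0.48 log units; beyond the scatter) and an at least 12-fold lower number from compound 2 to compound 3 (1.09 log units; beyond the scatter).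

Compound 4 `O=C1/C(=C\c2ccc(Cl)cc2)c2ccccc2N1c1c(Cl)cccc1Cl` differs from compound 3 by 4-chlorophenyl in place of 3-chlorophenyl on a double-bonded chain carbon bound to a double-bonded ring carbon. Both measured steps at this place exchanged the whole aryl group, and none moved a chlorine from one ring position to another, so they bear on this step only loosely. A step close to the scatter is expected, a 1.3-fold higher number from compound 3 to compound 4 (0.10 log units; within the scatter), and compound 4 is estimated at 10 ug/mL, within 4 ug/mL to 25 ug/mL.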

Compound 4, concentration for half-maximal effect: > 100 ug/mL
Compound 4 gave a limit, no number (the forecaster's own chance of this, stated with the estimate: 5%); middle value at least 10-fold (1.00 log units) away from the limit.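

In this assay, the place of the chlorine on this aryl group proves decisive: with the same atoms joined differently, 4-chlorophenyl in place of 3-chlorophenyl gives an at least 12-fold higher number from compound 3 to compound 4 (1.09 log units; beyond the scatter), a kind of change that the earlier whole-group exchanges could not isolate. A chlorine alone therefore does not secure a lower number, since chloro in place of hydroxy on an aromatic carbon gives an at least 3.0-fold higher number from compound 1 to compound 4 (0.48 log units; beyond the scatter), whereas the 3-chlorophenyl exchange gave a 4.1-fold lower number from compound 1 to compound 3 (0.62 log units; beyond the scatter). Compound 4 stands at a limit and not a number, as does compound 2, so the step between them cannot be read: the limit of > 100 ug/mL in this assay, at which 2 of the 4 values shown sit.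

This single pair shows the effect of moving a group for chlorine alone. As far as these compounds go, it remains open whether a bromine or a methoxy group in the place of that chlorine would keep the low number of compound 3.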